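The source may report more compounds than this note shows. Statements on the series, on what has been measured and on what is new or still open speak of the compounds shown alone.

Working notes on the series. Compound 1 `COc1ccc(-c2cc(C(=O)Nc3nc4ccc(Cl)cc4s3)nc3cc(-c4ccccc4)nn23)cc1OC` gives 6910 nM in a functional assay on MCF7 cells (Homo sapiens) for cytotoxicity, read by MTT assay, with a stated time of 48 h; a higher number here means a weaker inhibitor, a lower number a stronger inhibitor. Compound 2 `COc1cc(-c2cc(C(=O)Nc3nc4ccc(Cl)cc4s3)nc3cc(-c4ccccc4)nn23)cc(OC)c1OC` gives 30200 nM in this assay; it differs from compound 1 by methoxy in place of hydrogen on an aromatic carbon, and the step is a 4.4-fold higher number from compound 1 to compound 2 (0.64 log units; beyond the scatter). Compound 3 `COc1ccc(-c2cc(C(=O)Nc3nc4ccc(F)cc4s3)nc3cc(-c4ccccc4)nn23)cc1OC` gives 22400 nM in this assay; its core differs from that of compound 1 by fluoro in place of chloro on an aromatic carbon, a step of a 3.2-fold higher number from compound 1 to compound 3 (0.51 log units; beyond the scatter). Compound 4 `COc1cc(-c2cc(C(=O)Nc3nc4ccc(F)cc4s3)nc3cc(-c4ccccc4)nn23)cc(OC)c1OC` is not yet measured. It differs from compound 3 by methoxy in place of hydrogen on an aromatic carbon, the same change that turns compound 1 into compound 2, with the place described in identical words, so the change occurs twice among these compounds. Compound 4 is expected to show a step of a 3.8-fold higher number from compound 3 to compound 4 (0.58 log units; beyond the scatter), an expectation that rests on a 4.4-fold higher number from compound 1 to compound 2 (0.64 log units; beyond the scatter). The value expected for compound 4 in this assay is 85000 nM, estimated to fall between 30000 nM and 250000 nM.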

Compound 4, half-maximal inhibitory concentration: 27500 nM
Compound 4: middle estimate off by 3.1-fold (0.49 log units), on the high side; the whole stated range lies above it.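

In this assay the methoxy change does not carry over unchanged from the chloro compounds to the fluoro compounds, where it gives a 1.2-fold higher number from compound 3 to compound 4 (0.09 log units; within the scatter): the same change on two cores in this assay, a 4.4-fold higher number (0.64 log units; beyond the scatter) from compound 1 to compound 2 and a 1.2-fold higher number (0.09 log units; within the scatter) from compound 3 to compound 4, 3.6-fold (0.55 log units) apart, beyond the scatter of two such steps.

Fluoro in place of chloro likewise behaves differently once the third methoxy is present, giving a 1.1-fold lower number from compound 2 to compound 4 (0.04 log units; within the scatter): the same change on two cores in this assay, a 3.2-fold higher number (0.51 log units; beyond the scatter) from compound 1 to compound 3 and a 1.1-fold lower number (0.04 log units; within the scatter) from compound 2 to compound 4, 3.6-fold (0.55 log units) apart, beyond the scatter of two such steps.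

The two changes therefore do not add up across compound 1, compound 2, compound 3 and compound 4, but this single set of four compounds in one cell assay does not show why, or whether the same holds on any other core.

Open, as far as these compounds go, is how other groups would behave at these places, such as bromo or methyl in place of the halogen, or an amine in place of the added methoxy.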